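A Methyl Step Starting From a Limit

The source may hold more compounds than are shown below. What is called first, only, known or untested is meant among the compounds shown, and "the series" means these compounds.

Compound 1 `CCOC(=O)c1c(-c2cc(F)cc(OC)c2)[nH]c2cc(OC)ccc2c1=O` and compound 2 `CCOC(=O)c1c(-c2ccccc2)[nH]c2cc(OC)ccc2c1=O` share a core and were both tested in an ADME assay on Raji cells (Homo sapiens) for cytotoxicity, read by luminescence, with a stated time of 72 h; a higher number here means that more compound is needed for the effect, a lower number that less compound is needed. Compound 1 gives > 21500 nM, which is a limit. Compound 2 gives > 21500 nM, which is also a limit and not a number. Among the measured compounds shown here, the one measured step, a step that the two limits leave unreadable from compound 1 to compound 2, therefore has no readable size, and the only evidence is the limit of > 21500 nM in this assay, at which 2 of the 2 values shown sit. Compound 3 `CCOC(=O)c1c(-c2cccc(C)c2)[nH]c2cc(OC)ccc2c1=O` differs from compound 2 by methyl in place of hydrogen on an aromatic carbon. For the measured compounds named here, with no sized step to draw on, no change beyond the scatter is expected in this assay, and another limit is likely. The expected step is a number no higher from compound 2 to compound 3 (the limit leaves the size open). For compound 3 the estimate is 21500 nM, with an expected range of 9000 nM to 50000 nM.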

Compound 3, half-maximal effective concentration: > 21500 nM
Compound 3 ended at the assay's limit; the forecaster's own chance of this, stated with the estimate: 80%; the middle value sits exactly at the limit.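

Among the compounds shown here, compound 1, compound 2 and compound 3 all end at a limit rather than a number, so no step among them can be read: the limit of > 21500 nM in this assay, at which 3 of the 3 values shown sit. From the compounds shown here alone, whether any change on the shared core would give a readable number stays open.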